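This account rests on a few compounds, and the source may have more. Where it says the series, first, only, none or still open, it means among the compounds named here.

Compound 2 `CC(C)Cc1nn(-c2cccc(F)c2)cc1C(=O)NCc1ccncc1` is examined in a toxicity assay on HepG2 2.2.15 cells (Homo sapiens) for cytotoxicity, read by CCK-8 assay, with a stated time of 8 days; a higher number here means that more compound is tolerated, a lower number that less compound is tolerated. In this assay compound 2 reaches only > 100000 nM, which is a limit of the assay and not a number. The closely related compound 1 `CC(C)Cc1nn(-c2cccc(F)c2)cc1C(=O)NCc1ccccc1` gives 85900 nM in this assay. The step of an at least 1.1-fold higher number from compound 1 to compound 2 (0.06 log units; that floor lies within the scatter) lies within the usual scatter of such measurements. One of the two values sits at the limit of > 100000 nM in this assay, at which 1 of the 2 values shown sits. Compound 3 `CC(C)Cc1nn(-c2cccc(F)c2)cc1C(=O)NNc1ccc(F)cc1` differs from compound 2 by (4-fluorophenyl)amino in place of (pyridin-4-yl)methyl on an amide-type nitrogen. Going by the values given here, no measured step covers a change of this kind; the only known step, an at least 1.1-fold higher number from compound 1 to compound 2 (0.06 log units; that floor lies within the scatter), concerns a different exchange and is itself within the scatter, so it offers no direction for this one. The expected step is therefore about a number no higher from compound 2 to compound 3 (the limit leaves the size open), nothing beyond the scatter. Compound 3 is estimated at 100000 nM in this assay, with a range from 30000 nM to 300000 nM, and it may again reach only the limit.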

Compound 3, half-maximal cytotoxic concentration: 45400 nM
The estimate for compound 3 lay 2.2-fold (0.34 log units) above the measured number; the range from low to high includes it.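

Going by these compounds alone, on the amide-type nitrogen, (4-fluorophenyl)amino in place of (pyridin-4-yl)methyl gives the first step beyond the scatter in this assay, with an at least 2.2-fold lower number from compound 2 to compound 3 (0.34 log units; beyond the scatter). The size of that step is only a floor, because compound 2 stands at a limit of the assay and not at a number: the limit of > 100000 nM in this assay, at which 1 of the 3 values shown sits.

Against benzyl the same group gives a 1.9-fold lower number from compound 1 to compound 3 (0.28 log units; within the scatter), so this exchange shows no change that can be told from the scatter, and the clear step rests on compound 2 alone.

The step from compound 2 combines several changes at once: the ring nitrogen leaves, a fluorine enters, and an amino nitrogen replaces the chain carbon. On these data alone, it remains open which of these matters, and a phenylamino or 4-fluorobenzyl group on this nitrogen would help to separate them.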